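Replacing Cyclohexylmethoxy with (2,4-Dichlorophenyl)sulfanyl

The source may hold more compounds than are shown below. What is called first, only, known or untested is meant among the compounds shown, and "the series" means these compounds.

- Compound 1 `c1nc(OCC2CCCCC2)c2nc[nH]c2n1` gives 32300 nM
- Compound 2 `Fc1ccc(Sc2ncnc3[nH]cnc23)cc1` gives 31600 nM
- Compound 3 `c1ccc2c(c1)COC(n1cnc3c(OCC4CCCCC4)ncnc31)CO2` gives 11600 nM

These three values come from a functional assay on MCF7 cells (Homo sapiens) for antiproliferative activity, read by sulforhodamine B assay, with a stated time of 3 days; on this read-out lower numbers stand for stronger inhibition and higher numbers for weaker inhibition. Compound 3 has the lowest number of the three, at 11600 nM, and its gap to each of the other two lies beyond the usual scatter. Compound 1 and compound 2 stand within the scatter of each other.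

The next compound to be tested is compound 4 `Clc1ccc(Sc2ncnc3c2ncn3C2COc3ccccc3CO2)c(Cl)c1`. It carries (2,4-dichlorophenyl)sulfanyl in place of the cyclohexylmethoxy of compound 3, on an aromatic carbon of the shared core: (2,4-dichlorophenyl)sulfanyl in place of cyclohexylmethoxy on an aromatic carbon.

Within the data shown here, no measured pair isolates this exchange, so the expectation rests on limited evidence. Compound 1 at 32300 nM and compound 2 at 31600 nM offer no sign of a large difference in this assay. A modest step towards a lower number therefore seems more likely than a large one, though a result within the scatter of compound 3 would be no surprise. The expected change is a 2.3-fold lower number from compound 3 to compound 4 (0.37 log units; beyond the scatter). For compound 4 the estimated value is 5000 nM, with an expected range from 1500 nM to 20000 nM.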

Compound 4, half-maximal inhibitory concentration: 12000 nM
For compound 4 the middle estimate is 2.4-fold (0.38 log units) below the measured one; low and high end bracket the measured number.
By their numbers in this assay, from the lowest: compounds 3 and 4 (each within the scatter of the next); then compounds 2 and 1 (each within the scatter of the next).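

Among these compounds, compound 3 and compound 4 are the first pair here that differ in one place, and in this assay the exchange of cyclohexylmethoxy for (2,4-dichlorophenyl)sulfanyl on an aromatic carbon of the shared core gives a 1.0-fold higher number from compound 3 to compound 4 (0.01 log units; within the scatter). This step shows that, in this one pair, a six-membered non-aromatic ring of carbon only and a six-membered aromatic ring of carbon only, carried by different groups of similar heavy-atom count, are not told apart by this read-out at this position, with compound 4 at 12000 nM. The data offer no measured property that could account for this match between the two groups.

The compounds shown leave open whether the two chlorine atoms of the (2,4-dichlorophenyl)sulfanyl group contribute to this result, as no unsubstituted phenylsulfanyl or monochlorinated partner on this core stands among them. They also leave open whether a quite different group on this aromatic carbon, such as an amine, a carboxylic acid or a longer alkyl chain, would move the number beyond the scatter from that of compound 3.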